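Replacing the dichlorophenyl sulfone in a glutamate receptor ligand

A few compounds are considered here, and "the series" means these few. Any claim that something is new, unique, unknown or untested is made for them only; others in the source may bear on it.

Measured so far:
- compound 1, `CC1CCN(c2c(S(=O)(=O)c3cc(Cl)cc(Cl)c3)cnc3c(F)cccc23)CC1`: 82%
- compound 2, `CC1CCN(c2c(S(=O)(=O)c3ccc(F)c(F)c3)cnc3cc(F)ccc23)CC1`: 94%

Both compounds were examined in an assay on isolated protein for displacement of a labelled ligand from metabotropic glutamate receptor 5 (Homo sapiens), with a stated time of 60 min, tested at 1 uM; a higher number here means more inhibition at the concentration tested (going by the name of the read-out), a lower number less inhibition. Compound 1 gives 82%, which is the lower of the two numbers recorded. Compound 2 gives 94%, a result that sits beyond the usual scatter above compound 1, so the inhibition in this assay is lower for compound 1 than for compound 2. For the measured compounds named here, no single-point step between measured compounds is available, so the effect of changing the aryl group on the sulfonyl sulfur has not yet been seen directly.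

Compound 3, `CC1CCN(c2c(S(=O)(=O)c3ccc(F)cc3)cnc3c(F)cccc23)CC1`, follows from compound 1 by the change (4-fluorophenyl in place of 3,5-dichlorophenyl on a sulfonyl sulfur). The smaller aryl group carries one fluorine in place of two chlorines. With only the two measured values to go on, a modest step is expected in this assay, most likely downward from compound 1 or not clearly beyond the scatter. The expected step of a number 6 percentage points lower from compound 1 to compound 3 (within the scatter) reflects that view. Compound 3 is estimated at 76%, within a range from 55% to 92%.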

Compound 3, a percentage reported as inhibition, at one concentration (the size of the read-out at that concentration, not a potency): 26%
Compound 3: middle estimate off by 50 percentage points, on the high side; the whole stated range lies above it.
By their numbers in this assay, from the lowest: compound 3; then compound 1; then compound 2.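

In this assay, the aryl group on the sulfonyl sulfur proves to be a sensitive position: with the rest of the structure held constant, 4-fluorophenyl in place of 3,5-dichlorophenyl gives a number 56 percentage points lower from compound 1 to compound 3 (beyond the scatter). For the compounds shown here, this is the first direct reading of a change at this position, as the two earlier compounds differ from each other in more than one place and could show only two separate values. Nothing available bears on why this step is so large.

The change alters the kind of halogen, the number of halogens and where they stand on the phenyl ring all at once, so the data cannot say which of these differences accounts for the step, or whether the chlorines of compound 1 matter in themselves. Going by these compounds, an unsubstituted phenyl group, or a phenyl ring carrying methyl or methoxy groups in place of the chlorines, would help to separate these possibilities, while the other parts of the shared core remain untested by any single change.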